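The source may report more compounds than this note shows. Statements on the series, on what has been measured and on what is new or still open speak of the compounds shown alone.

an ADME assay on Raji cells (Homo sapiens) for cytotoxicity, read by CellTiter-Glo and resazurin assay, with a stated time of 72 h (on this read-out lower numbers stand for an effect already at smaller amounts and higher numbers for an effect only at larger amounts of compound), is the measure used for this whole set. Compound 1 `CC(=O)Nc1cccc(-c2ccc(C(=O)N(Cc3cccc(OCCCCCC(=O)O)c3)C(C)C)cc2)c1` gives > 26000 nM in this assay, which is a limit of the assay rather than a number. Compound 2 `CC(C)N(Cc1cccc(OCCCCCC(=O)O)c1)C(=O)c1ccc(-c2ccsc2)cc1` gives > 26000 nM in this assay, again a limit. The one-place step between them, a step that the two limits leave unreadable from compound 1 to compound 2, therefore cannot be read. Compound 3 `CCOC(=O)CCCCCOc1cccc(CN(C(=O)c2ccc(-c3cnc(OC)nc3OC)cc2)C(C)C)c1` gives > 26000 nM in this assay, also a limit. Compound 3 thus stands where every measured compound stands: the limit of > 26000 nM in this assay, at which 3 of the 3 values shown sit, so nothing in the numbers shown sets it apart from the others.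

Compound 4 `CCOC(=O)CCCCCOc1cccc(CN(C(=O)c2ccc(-c3cccc(-c4nnc(C)o4)c3)cc2)C(C)C)c1` is the unmeasured compound. It differs from compound 3 in one place: 3-(5-methyl-1,3,4-oxadiazol-2-yl)phenyl in place of 2,4-dimethoxypyrimidin-5-yl on an aromatic carbon. The 3-(5-methyl-1,3,4-oxadiazol-2-yl)phenyl group takes the place held by the 2,4-dimethoxypyrimidin-5-yl group in compound 3, with the shared core otherwise unchanged. Among the measured compounds shown here, no measured step bears directly on this change, and the only one-place step available, a step that the two limits leave unreadable from compound 1 to compound 2, cannot be read. With all three values sitting at the limit, no direction can be drawn from the data, and the likeliest outcome is that compound 4 also reaches only the limit. Compound 4 is therefore expected to give about 30000 nM in this assay, between 15000 nM and 80000 nM, which means an expected step that the limit leaves unreadable from compound 3 to compound 4.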

Compound 4, half-maximal effective concentration: > 26000 nM
Compound 4 gave a limit, no number (the forecaster's own chance of this, stated with the estimate: 85%); the middle value is on the limit's open side.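

The step from compound 3 to compound 4 cannot be read, since both values are limits of the assay and not numbers: the limit of > 26000 nM in this assay, at which 4 of the 4 values shown sit.

The compounds shown leave open whether any change to the shared core would give an actual number in this assay, and how far each compound lies beyond that limit.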